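Phenyl on the Ring Nitrogen of a Hydroxamic Acid Series

This account rests on a few compounds, and the source may have more. Where it says the series, first, only, none or still open, it means among the compounds named here.

Measured so far:
compound 1, `O=C(CCCCCCc1nc2ccccc2[nH]1)NO`, 2700 nM
compound 2, `O=C(CCCCCCc1nc2ccc(-c3cccc(F)c3)cc2[nH]1)NO`, 1500 nM
compound 3, `COc1ccc2nc(CCCCCCC(=O)NO)[nH]c2c1`, 11000 nM

In a functional assay on SK-OV-3 cells (Homo sapiens) for cytotoxicity (a higher number here means a weaker inhibitor, a lower number a stronger inhibitor), compound 1 stands second highest of the three numbers. Compound 2 lies near it, the step of a 1.8-fold lower number from compound 1 to compound 2 (0.26 log units; within the scatter) falling within the scatter, while compound 3 gives the furthest number, the step of a 4.1-fold higher number from compound 1 to compound 3 (0.61 log units; beyond the scatter) lying beyond it.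

Compound 4, `O=C(CCCCCCc1nc2ccccc2n1-c1ccccc1)NO`, is not yet measured. It differs from compound 1 by phenyl in place of hydrogen on an aromatic nitrogen. Neither measured step touches the ring nitrogen: adding a 3-fluorophenyl on an aromatic carbon gave a 1.8-fold lower number from compound 1 to compound 2 (0.26 log units; within the scatter), adding a methoxy gave a 4.1-fold higher number from compound 1 to compound 3 (0.61 log units; beyond the scatter). These bear only loosely on compound 4, so a step close to the scatter in this assay is expected, with wide uncertainty. Compound 4 is estimated at 3000 nM, between 1200 nM and 8000 nM, which means an expected step of a 1.1-fold higher number from compound 1 to compound 4 (0.05 log units; within the scatter).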

Compound 4, half-maximal inhibitory concentration: > 20000 nM
Compound 4: a limit, no number (the forecaster's own chance of this, stated with the estimate: 10%); at least 6.6-fold (0.82 log units) between middle value and limit.
By their numbers in this assay, from the lowest: compounds 2 and 1 (each within the scatter of the next); then compound 3. At a limit, above all of these: compound 4.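

Phenyl in place of hydrogen on an aromatic nitrogen gives an at least 7.4-fold higher number from compound 1 to compound 4 (0.86 log units; beyond the scatter) in this assay, the first sign that a substituent on this ring nitrogen can weaken the compound. An added aromatic ring is not tied to such a rise wherever it sits: 3-fluorophenyl on an aromatic carbon gives a 1.8-fold lower number from compound 1 to compound 2 (0.26 log units; within the scatter). The result for compound 4 is a limit, not a number: the limit of > 20000 nM in this assay, at which 1 of the 4 values shown sits.

From the compounds shown here alone, whether a methyl group on this nitrogen would keep the number of compound 1 remains open. So does the effect of a benzyl group or an amine-bearing phenyl there.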